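This account rests on a few compounds, and the source may have more. Where it says the series, first, only, none or still open, it means among the compounds named here.

In a functional assay on MCF7 cells (Homo sapiens) for cytotoxicity, read by MTT assay, with a stated time of 72 h (a higher number here means a weaker inhibitor, a lower number a stronger inhibitor), compound 1 `COc1cccc(/C=C2\CCC/C(=C\c3cccc(Cl)c3)C2=O)c1OC` gives 12000 nM, compound 2 `COc1cccc(/C=C2\CCC/C(=C\c3ccccc3Br)C2=O)c1OC` gives 9700 nM and compound 3 `COc1cccc(/C=C2\CCC/C(=C\c3cccc(Br)c3)C2=O)c1OC` gives 11700 nM. Compound 3 therefore stands within the scatter of both others, and the three values show no real order. Compound 4 `COc1cccc(/C=C2\CCC/C(=C\c3cccc(O)c3)C2=O)c1OC` differs from compound 3 as follows: hydroxy in place of bromo on an aromatic carbon. This places hydroxy in place of bromo on an aromatic carbon, turning 3-bromophenyl into 3-hydroxyphenyl. For the measured compounds named here, three measured steps bear on this change, though only indirectly. Bromo in place of chloro gave a 1.0-fold lower number from compound 1 to compound 3 (0.01 log units; within the scatter), 3-bromophenyl in place of 2-bromophenyl gave a 1.2-fold higher number from compound 2 to compound 3 (0.08 log units; within the scatter), and the remaining pair gave a 1.2-fold lower number from compound 1 to compound 2 (0.09 log units; within the scatter). Going by the values given here, all three lie within the scatter, but they cover halogen changes only, and no measured compound carries hydroxy. No step beyond the scatter is therefore expected, and this expectation is a loose one. The estimated step is a 1.3-fold lower number from compound 3 to compound 4 (0.11 log units; within the scatter). For compound 4 the estimated value is 9000 nM, with an expected range from 3500 nM to 22000 nM.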

Compound 4, half-maximal inhibitory concentration: 8800 nM
Beside the measured number, compound 4's estimate is 1.0-fold (0.01 log units) above it; measured number inside the range.
By their numbers in this assay, from the lowest: compounds 4, 2, 3 and 1 (each within the scatter of the next).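

For the compounds shown here, compound 4 is the first here to carry something other than a halogen on this aromatic carbon, a hydroxy with a hydrogen-bond donor and acceptor where bromo has neither, and in this assay this replacement gives a 1.3-fold lower number from compound 3 to compound 4 (0.12 log units; within the scatter). Set against the chloro and 2-bromophenyl compounds, it gives a 1.4-fold lower number from compound 1 to compound 4 (0.13 log units; within the scatter) and a 1.1-fold lower number from compound 2 to compound 4 (0.04 log units; within the scatter), so the flat picture seen among the halogen compounds now extends to a non-halogen group. Nothing measured here offers an explanation for this flatness.

As far as these compounds go, whether an amine or a carboxylic acid on the same aromatic carbon would also stay within the scatter remains open. From the compounds shown here alone, the dimethoxy-substituted side of the shared core is also the same in all four compounds, so what a change there would do is unknown.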